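Shortening the chain from compound 2 to compound 4

The compounds below may be only part of what the source reports. "The series", "measured", "known", "first", "only" and "open" are said of these compounds alone.

compound 1 `COc1ccc(N(C)c2nc(C)nc3ccccc23)cc1OCCC[Se]C#N`: 852 nM
compound 2 `COc1ccc(N(C)c2nc(C)nc3ccccc23)cc1OCCCCCC[Se]C#N`: 6180 nM
compound 3 `Cc1nc(N(C)c2ccc([Se]C#N)c(C)c2)c2ccccc2n1`: 13 nM

All three values come from a functional assay on HCT-116 cells (Homo sapiens) for inhibition, read by MTT assay, with a stated time of 48 h; on this read-out lower numbers stand for stronger inhibition and higher numbers for weaker inhibition. Compound 2 stands highest of the three numbers. The change to compound 4 `COc1ccc(N(C)c2nc(C)nc3ccccc23)cc1C[Se]C#N` is a group of 4 heavy atoms (2 carbon, 1 nitrogen, 1 selenium; no ring) in place of a group of 10 heavy atoms (7 carbon, 1 nitrogen, 1 oxygen, 1 selenium; no ring), on an aromatic carbon. The new group sits ortho to a methoxy group.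

Among the compounds with values here, one measured step bears directly on this change: a 7.3-fold higher number from compound 1 to compound 2 (0.86 log units; beyond the scatter). This modest step, beyond the scatter, links the longer chain with the higher number, but it rests on a single pair. Within the data shown here, compound 4 loses more of the chain than compound 1 does, and it also loses the oxygen, a change no measured step isolates. Compound 3 at 13 nM differs from compound 4 in more than one place, so it is only a loose guide to how low the number could go.

A larger step than the measured one is therefore expected, towards a lower number. For compound 4 the estimated value is 120 nM, with an expected range from 20 nM to 700 nM. The estimated change is a 52-fold lower number from compound 2 to compound 4 (1.71 log units; beyond the scatter).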

Compound 4, half-maximal inhibitory concentration: 113 nM
Beside the measured number, compound 4's estimate is 1.1-fold (0.03 log units) above it; the range from low to high includes it.
By their numbers in this assay, from the lowest: compound 3; then compound 4; then compound 1; then compound 2.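

In this assay, the group of 4 heavy atoms on this aromatic carbon carries the fall in number further than the three-carbon ether chain of compound 1 had, with a 7.5-fold lower number from compound 1 to compound 4 (0.88 log units; beyond the scatter) on that shorter comparison and a 55-fold lower number from compound 2 to compound 4 (1.74 log units; beyond the scatter) across the whole change. Across compound 2, compound 1 and compound 4, the number therefore falls each time the group at this position gets smaller, and none of the three goes against that order. No measurement given here accounts for this fall.

The oxygen leaves together with the chain carbons, so a plain carbon chain without the oxygen would be needed to tell the two changes apart. From the compounds shown here alone, how an amine or a carboxylic acid at the end of a short chain on this aromatic carbon would compare also remains open.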